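The source may hold more compounds than are shown below. What is called first, only, known or untested is meant among the compounds shown, and "the series" means these compounds.

Working notes on the quinoline-type series examined in a functional assay on PC-3 cells (Homo sapiens); a lower number here means a stronger inhibitor of growth, a higher number a weaker inhibitor of growth.

Compound 1 `Cc1cc(C)c2c(O)cc(-c3ccc(Cl)cc3)nc2n1` gives 6310 nM in this assay. Compound 2 `Cc1ccnc2nc(-c3ccc(Cl)cc3)cc(O)c12` gives 2880 nM in this assay. Compound 3 `COc1ccccc1-c1cc(O)c2cccnc2n1` gives 29500 nM in this assay and stands highest of the three measured numbers; the gap to compound 1 and the gap to compound 2 are both beyond the scatter.

Compounds 1 and 2 differ in one place, (methyl in place of hydrogen on an aromatic carbon), and the step is a 2.2-fold higher number from compound 2 to compound 1 (0.34 log units; beyond the scatter). Compound 3 carries a different core from compound 2; the difference between the two cores is not broken down here.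

Compound 4 `COc1ccccc1-c1cc(O)c2c(C)ccnc2n1` is not yet measured. It is made from compound 3 by methyl in place of hydrogen on an aromatic carbon. For the measured compounds named here, this is the same kind of change as the one from compound 2 to compound 1, but the surroundings of the place differ: in compound 1 the methyl sits next to the ring nitrogen, meta to a fused ring, meta to a methyl group and para to a fused ring, whereas in compound 4 it sits ortho to a fused ring, meta to a fused ring and opposite the ring nitrogen. Going by the values given here, the only precedent for adding a methyl on this ring, compound 2 to compound 1, gave a 2.2-fold higher number from compound 2 to compound 1 (0.34 log units; beyond the scatter), a modest worsening. On that single step, and with the different core and different place, a step of similar size is expected, a 1.7-fold higher number from compound 3 to compound 4 (0.23 log units; within the scatter), with wide uncertainty. Compound 4 is therefore estimated at 50000 nM, within 20000 nM to 120000 nM, in this assay.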

Compound 4, concentration for 50% growth inhibition: 20900 nM
Compound 4: the middle estimate sits 2.4-fold (0.38 log units) above what was measured, within the range that was stated.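

In this assay, methyl in place of hydrogen on an aromatic carbon gives a 1.4-fold lower number from compound 3 to compound 4 (0.15 log units; within the scatter), so on the core of compound 3 the change does not move the number beyond what repeated measurements would scatter. Set beside the earlier step, the same change does not give the same result on the two cores: the same change on two cores in this assay, a 2.2-fold higher number (0.34 log units; beyond the scatter) from compound 2 to compound 1 and a 1.4-fold lower number (0.15 log units; within the scatter) from compound 3 to compound 4, 3.1-fold (0.49 log units) apart, beyond the scatter of two such steps This shows that, across these two pairs, the modest worsening seen on the core of compound 2 does not carry over as a fixed increment; it does not show which difference between the pairs accounts for the gap, since the cores, the aryl substituents and the place of the methyl all vary together, and two steps cannot separate them or establish a rule for the series.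

Still open, on these data alone, is whether anything other than methyl at the place opposite the ring nitrogen, such as an amine, a carboxylic acid or a longer chain, would move the number beyond the scatter on either core. Also open, as far as these compounds go, is how growth inhibition responds when the hydroxyl group shared by all four compounds gives way to a methoxy group or an amine.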